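This account rests on a few compounds, and the source may have more. Where it says the series, first, only, none or still open, it means among the compounds named here.

Measured so far:
- Compound 1 `COc1cc2c(c(OC)c1O)C(=O)[C@H](O)[C@@H](c1ccc(O)cc1)O2`: 19.1%
- Compound 2 `COc1cc2c(c(OC)c1OC)C(=O)[C@H](O)[C@@H](c1ccc(O)cc1)O2`: 17.1%

Among the measured compounds shown here, in a functional assay on PC-12 cells (Rattus norvegicus) for cytotoxicity, read by MTT assay, with stated times of 2 h and 4 h, tested at 32 ug/mL (on this read-out higher numbers stand for a stronger effect at the one concentration tested and lower numbers for a weaker effect), compound 2 stands lowest of the two numbers, its nearest neighbour being compound 1; the one measured step, a number 2 percentage points lower from compound 1 to compound 2 (within the scatter), lies within the scatter. Compound 3 `COc1cc2c(c(OC)c1OC)C(=O)[C@H](O)[C@@H](c1ccc(O)c(O)c1)O2` is to be measured in this assay and differs from compound 2 by hydroxy in place of hydrogen on an aromatic carbon. For the measured compounds named here, no measured step concerns a hydroxy entering an aromatic ring, and the only step available is within the scatter, so for compound 3 no step beyond the scatter is expected, a number 2.9 percentage points higher from compound 2 to compound 3 (within the scatter). Compound 3 is therefore estimated at 20%, with a range from 8% to 34%.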

Compound 3, a percentage reported as activity, at one concentration (the size of the read-out at that concentration, not a potency): 74.5%
Compound 3: the middle estimate sits 54.5 percentage points below what was measured, outside the stated range (above it).
By their numbers in this assay, from the lowest: compounds 2 and 1 (each within the scatter of the next); then compound 3.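

In this assay, hydroxy in place of hydrogen on an aromatic carbon ortho to a hydroxy group gives a number 57.4 percentage points higher from compound 2 to compound 3 (beyond the scatter) and turns 4-hydroxyphenyl into 3,4-dihydroxyphenyl. Among the compounds shown here, this is the first step beyond the scatter, whereas the methyl change on the aromatic oxygen gave only a number 2 percentage points lower from compound 1 to compound 2 (within the scatter) and so showed no such sensitivity. Nothing available bears on the reason for this rise.

On these data alone, whether an amine or a carboxylic acid at this position would give a similar number remains open. So does whether the rise depends on the hydroxy group already on that ring.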